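Aryl replacement on the core of compound 3

This account rests on a few compounds, and the source may have more. Where it says the series, first, only, none or still open, it means among the compounds named here.

Measured in an assay on Ltk cells with metabotropic glutamate receptor 5 (Homo sapiens) as the target, read by fluorescence and calcium flux; on this read-out higher numbers stand for weaker inhibition and lower numbers for stronger inhibition:
compound 1 `COc1cccnc1Nc1cccc(C)n1`: 458 nM
compound 2 `CCOc1c(C)ccnc1Nc1cccc(C)n1`: 2700 nM
compound 3 `CCOc1cc(-c2ccc(C)cc2)cnc1Nc1cccc(C)n1`: 513 nM

Compound 3 gives the second highest of the three numbers in this assay. Its nearest neighbour is compound 1, whose number is lower by a margin within the scatter, so no order between compound 1 and compound 3 can be stated. Compound 2 stands furthest from compound 3, with a number higher by a margin beyond the scatter.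

Compound 4 `CCOc1cc(-c2cccnc2C#N)cnc1Nc1cccc(C)n1` has not yet been measured. It differs from compound 3 in one place: 2-cyanopyridin-3-yl in place of 4-methylphenyl on an aromatic carbon. For the measured compounds named here, no pair of measured compounds differs only in this place, so no measured step can guide the expectation directly; what the series shows is that the two compounds carrying an ethoxy group, compound 2 and compound 3, lie far apart, while compound 1 and compound 3 lie together.

The step of a 1.7-fold lower number from compound 3 to compound 4 (0.23 log units; within the scatter) is expected to stay within the scatter, with a somewhat lower number if anything. The estimate for compound 4 in this assay is 300 nM, with a range from 80 nM to 1500 nM.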

Compound 4, half-maximal inhibitory concentration: 80 nM
For compound 4 the middle estimate is 3.8-fold (0.57 log units) above the measured one, within the range that was stated.
By their numbers in this assay, from the lowest: compound 4; then compounds 1 and 3 (each within the scatter of the next); then compound 2.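

In this assay, the aromatic carbon para to the (6-methylpyridin-2-yl)amino group proves sensitive to the group it carries: 2-cyanopyridin-3-yl in place of 4-methylphenyl gives a 6.4-fold lower number from compound 3 to compound 4 (0.81 log units; beyond the scatter). For the compounds shown here, this is the first step that isolates one place, and it shows that an aryl group here can be exchanged with a gain in inhibition, the change going with a ring nitrogen and a nitrile entering and the count of hydrogen-bond acceptors rising from 0 to 2. No measurement shown here accounts for the shift, so the step stands as an observation only.

The step changes the ring nitrogen, the nitrile and the loss of the methyl group all at once, so the compounds shown do not assign the lower number to any one of them; pyridin-3-yl without the nitrile and 2-cyanophenyl with a carbon-only ring would separate these contributions. As far as these compounds go, it also remains open whether this place accepts anything other than a six-membered aromatic ring, such as a morpholine or a carboxylic acid.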